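Aryl variation on a shared core: cytotoxicity working notes

The source may report more compounds than this note shows. Statements on the series, on what has been measured and on what is new or still open speak of the compounds shown alone.

Measured so far in an ADME assay on HEL cells (Homo sapiens) for cytotoxicity, with a stated time of 3 days; on this read-out lower numbers stand for higher toxicity in this test and higher numbers for lower toxicity in this test:
- compound 1 `Cc1cc(-c2ccccc2)c2ncc(CSCCc3ccccc3)n2c1` gives 33 ug/mL
- compound 2 `Cc1cc(-c2ccsc2)c2ncc(CSCCc3ccccc3)n2c1` reaches > 50 ug/mL
- compound 3 `Cc1cc(-c2ccccc2)cn2c(CSCCc3ccccc3)cnc12` gives 31 ug/mL

Compound 2 stands only at a limit of this assay, not at a number; it is the one of the three that sits at the limit of > 50 ug/mL in this assay, at which 1 of the 3 values shown sits. Compound 1 and compound 3, both carrying phenyl on differently arranged cores, give numbers that lie within the scatter of each other, so no order between them is claimed.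

Going by the values given here, the one measured step that touches an aryl swap is an at least 1.5-fold higher number from compound 1 to compound 2 (0.18 log units; that floor lies within the scatter). Its floor lies within the scatter, so the true size of that step is open.

Compound 4 `COc1ccc(-c2cc(C)cn3c(CSCCc4ccccc4)cnc23)cc1` is not yet measured. Relative to compound 2 the change is 4-methoxyphenyl in place of thiophen-3-yl on an aromatic carbon. Among the compounds with values here, no measured step covers 4-methoxyphenyl at this position; the only guides are the phenyl numbers of compound 1 and compound 3 and the limit of compound 2. A number near the phenyl pair, with wide uncertainty and a real chance of another limit, is therefore expected. For compound 4 the expected result in this assay is 35 ug/mL, with a range from 15 ug/mL to 80 ug/mL. This estimate implies a step of an at least 1.4-fold lower number from compound 2 to compound 4 (0.15 log units; that floor lies within the scatter).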

Compound 4, half-maximal cytotoxic concentration: 19.6 ug/mL
Compound 4: the middle estimate sits 1.8-fold (0.25 log units) above what was measured; low and high end bracket the measured number.
By their numbers in this assay, from the lowest: compounds 4, 3 and 1 (each within the scatter of the next). At a limit, above all of these: compound 2.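

In this assay this position now shows a step beyond the scatter, an at least 2.5-fold lower number from compound 2 to compound 4 (0.40 log units; beyond the scatter), whereas the earlier step from phenyl to thiophen-3-yl, an at least 1.5-fold higher number from compound 1 to compound 2 (0.18 log units; that floor lies within the scatter), stayed within it at its floor. Compound 2 remains a limit and not a number, so the step to 4-methoxyphenyl is known only as a floor: the limit of > 50 ug/mL in this assay, at which 1 of the 4 values shown sits. Methoxy in place of hydrogen on the phenyl gives a 1.7-fold lower number from compound 1 to compound 4 (0.23 log units; within the scatter), which leaves compound 1 and compound 4 unseparated, so among the aryl groups on the shared core only thiophen-3-yl and 4-methoxyphenyl are set apart.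

Going by these compounds, the true size of both steps involving compound 2 stays open, since neither can be fixed while that compound has only a limit, and one thiophen-3-yl example cannot show whether the separation holds for other five-membered aromatic rings. Also open, on these data alone, is whether an amine or a carboxylic acid in place of the methoxy group on the same phenyl ring would move the number beyond the scatter from compound 1.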